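The source may hold more compounds than are shown below. What is called first, only, known or untested is meant among the compounds shown, and "the series" means these compounds.

Measured compounds:
Compound 1, `CCCNCC(=O)N1N=C(c2cc3ccccc3oc2=O)CC1c1ccccc1`, gives 7270 nM in a functional assay on PC-3 cells (Homo sapiens) for cytotoxicity, read by MTT assay, with a stated time of 48 h; a higher number here means a weaker inhibitor, a lower number a stronger inhibitor.
Compound 2, `O=C(CNC1CCCCC1)N1N=C(c2cc3ccccc3oc2=O)CC1c1ccccc1`, gives 48500 nM in this assay.
Compound 3, `O=C(CN1CCCC1)N1N=C(c2cc3ccccc3oc2=O)CC1c1ccccc1`, gives 50200 nM in this assay.

Compound 3 carries the highest of the three numbers in this assay. Its nearest neighbour is compound 2, and the gap a 1.0-fold higher number from compound 2 to compound 3 (0.01 log units; within the scatter) lies within the scatter, so the two are not separable. The furthest is compound 1, from which the step of a 6.9-fold higher number from compound 1 to compound 3 (0.84 log units; beyond the scatter) is beyond the scatter.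

Compound 4, `CC1CC(C)CN(CC(=O)N2N=C(c3cc4ccccc4oc3=O)CC2c2ccccc2)C1`, differs from compound 3 by 3,5-dimethylpiperidin-1-yl in place of pyrrolidin-1-yl on a saturated chain carbon bound to a carbonyl carbon. Going by the values given here, no measured pair changes one cyclic amine for another of a different ring size, so the closest guide is the step of a 1.0-fold higher number from compound 2 to compound 3 (0.01 log units; within the scatter), which shows that a six-membered carbocycle on the amine nitrogen and a five-membered nitrogen ring land in the same place. The step of a 6.7-fold higher number from compound 1 to compound 2 (0.82 log units; beyond the scatter) shows that the one open-chain amine, compound 1, is the outlier among the three, not the cyclic ones. On that basis compound 4 is expected to sit close to compound 3, with an expected step of a 1.1-fold lower number from compound 3 to compound 4 (0.05 log units; within the scatter) that does not clearly exceed the scatter. The estimate for compound 4 is 45000 nM, with a range from 18000 nM to 110000 nM.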

Compound 4, half-maximal inhibitory concentration: "not active" (no number reported)
Compound 4 has no reported number here, so the estimate cannot be set against anything.
By their numbers in this assay, from the lowest: compound 1; then compounds 2 and 3 (each within the scatter of the next).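

Going by these compounds alone, compound 4 is reported as not active in this assay, with no number, so no step between it and compound 1, compound 2 or compound 3 can be read. The compounds shown leave open how far 3,5-dimethylpiperidin-1-yl separates from pyrrolidin-1-yl on this scale. No measurement given here explains this result.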